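This account rests on a few compounds, and the source may have more. Where it says the series, first, only, none or still open, it means among the compounds named here.

Measured so far:
Compound 1 `CCn1c(CNc2ccccc2)nnc1SCC(=O)Nc1ccc(C(C)=O)cc1` — in an assay on isolated protein for inhibition of long-chain fatty acid transport protein 1 (Mus musculus) (a lower number here means a stronger inhibitor, a higher number a weaker inhibitor), compound 1 gives "not determined" (no result reported).
Compound 2 `CCn1c(CNc2ccccc2)nnc1SCc1nc2cc(C)ccc2o1` — in this assay compound 2 gives > 10000 nM, which is a limit of the assay and not a number.

Compound 1 and compound 2 share the same core and differ only in the group carried on the sulfur-linked chain. Within the data shown here, for compound 1 no number exists in this assay, so its standing can be read only from what surrounds it, and the one further value shown is the limit of > 10000 nM in this assay, at which 1 of the 2 values shown sits. Among the measured compounds shown here, that leaves no measured step at all from which the effect of a structural change could be gauged.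

Compound 3 `CCn1c(CNc2ccccc2)nnc1SCC(=O)Nc1ccc(Cl)cc1` keeps everything of compound 1 except the group on the six-membered aromatic ring of carbon only: chloro in place of acetyl on an aromatic carbon. For the measured compounds named here, this is a small change on the outer edge of the molecule, and with no measured pair to lean on, the size of any step in this assay cannot be foreseen; the expectation is no step beyond the scatter in either direction. Given that the only number in this series sits at the limit, compound 3 is expected to come in around 15000 nM, in a range from 3000 nM to 60000 nM, with a fair chance that only a limit is reported.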

Compound 3, half-maximal inhibitory concentration: > 10000 nM
Compound 3: a limit, no number; the forecaster's own chance of this, stated with the estimate: 70%; the middle value is on the limit's open side.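

Among these compounds, compound 1 has no number in this assay, so no step to compound 3 can be read. In this assay compound 3 gives > 10000 nM, which is a limit and not a number. The compounds shown leave open which structural change, if any, would bring a measurable inhibition, and the values so far offer only this: the limit of > 10000 nM in this assay, at which 2 of the 3 values shown sit.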